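The compounds below may be only part of what the source reports. "The series", "measured", "known", "first", "only" and "open" are said of these compounds alone.

Compound 3 `CN(C)CCCCCSC1=Nc2ccccc2C(CC(=O)NCc2ccccc2)N1c1ccc(-c2ccccc2)cc1` holds the lowest number of the three compounds measured in an assay on cells for inhibition of Voltage-dependent T-type calcium channel subunit alpha-1I (Homo sapiens), read by patch clamp; on this read-out lower numbers stand for stronger inhibition and higher numbers for weaker inhibition: compound 3 gives 1760 nM. Compound 1 `CN(C)CCCCCSC1=Nc2ccccc2C(CC(=O)NCc2ccccc2)N1c1ccc(-c2ccc(F)cc2)cc1` gives 9060 nM in this assay, and compound 2 `O=C(CC1c2ccccc2N=C(SCCCCCN2CCCC2)N1c1ccc(-c2ccccc2)cc1)NCc1ccc(F)cc1` gives 13600 nM. Among the measured compounds shown here, the one single-point step within these data, a 5.1-fold lower number from compound 1 to compound 3 (0.71 log units; beyond the scatter), concerns a fluoro on the biphenyl portion of the shared core, not the benzylamide end.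

Compound 4 `CN(C)CCCCCSC1=Nc2ccccc2C(CC(=O)NCc2ccc(F)cc2)N1c1ccc(-c2ccccc2)cc1` differs from compound 3 by fluoro in place of hydrogen on an aromatic carbon, on the benzyl of the amide, para to a large group. For the measured compounds named here, no measured step addresses this exact change. Compound 2 also carries a 4-fluorobenzyl amide, but it differs from compound 3 in a second place as well, so its higher number can only be noted, not assigned to the fluoro. With that weak guide, a moderate rise in the number is expected for compound 4, a step of about a 2.6-fold higher number from compound 3 to compound 4 (0.41 log units; beyond the scatter). Compound 4 is therefore estimated at 4500 nM in this assay, within a range from 1500 nM to 14000 nM.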

Compound 4, half-maximal inhibitory concentration: 6100 nM
For compound 4 the middle estimate is 1.4-fold (0.13 log units) below the measured one, and the stated range covers the measured number.
By their numbers in this assay, from the lowest: compound 3; then compounds 4, 1 and 2 (each within the scatter of the next, the first and the last beyond it).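

In this assay, the benzyl of the amide now has its own direct reading: fluoro in place of hydrogen there gives a 3.5-fold higher number from compound 3 to compound 4 (0.54 log units; beyond the scatter). This is the same direction as on the biphenyl portion, where removing a fluoro gave a 5.1-fold lower number from compound 1 to compound 3 (0.71 log units; beyond the scatter), so among these compounds a 4-fluorophenyl at either end goes with a higher number than the plain phenyl. Among the compounds shown here, the result also lets the amine end be read apart from the amide for the first time, since with the 4-fluorobenzyl amide held in place, dimethylamino in place of pyrrolidin-1-yl gives a 2.2-fold lower number from compound 2 to compound 4 (0.35 log units; beyond the scatter), and no measurement offered here explains any of these steps.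

The compounds shown leave open whether chloro or methoxy in the same place on the benzyl would also raise the number. They also leave open whether a piperidin-1-yl or a shorter chain at the amine end would shift it, and whether that end behaves the same with the plain benzyl amide.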